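Swapping a Nitro for a Methyl: Expected Cytotoxicity

The compounds below may be only part of what the source reports. "The series", "measured", "known", "first", "only" and "open" are said of these compounds alone.

compound 1 `CSc1nc(NCCCNc2ccnc3cc(Cl)ccc23)c(C#N)c(-c2ccccc2)n1`: 20000 nM
compound 2 `CSc1nc(NCCCCNc2ccnc3cc(Cl)ccc23)c(C#N)c(-c2ccc([N+](=O)[O-])cc2)n1`: 4000 nM
compound 3 `CSc1nc(-c2ccc([N+](=O)[O-])cc2)c(C#N)c(N2CCN(c3ccnc4cc(Cl)ccc34)CC2)n1`: >= 100000 nM (a limit of the assay, not a number)

Of the compounds shown here, three have been tested in an ADME assay on HEL cells (Homo sapiens) for cytotoxicity, read by microscopy; a higher number here means that more compound is tolerated, a lower number that less compound is tolerated. Compound 1 gives 20000 nM. Compound 2 gives 4000 nM. For compound 3 the assay reports only a limit, >= 100000 nM. Among the two numbers, compound 2 stands at the lowest, and compound 1 sits higher by a margin beyond the usual scatter.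

Compound 4 `CSc1nc(NCCCCNc2ccnc3cc(Cl)ccc23)c(C#N)c(-c2ccc(C)cc2)n1` differs from compound 2 in one place: methyl in place of nitro on an aromatic carbon. Among the compounds with values here, no measured pair isolates this change, so its effect is uncertain. A modest rise in tolerated concentration is expected, since compound 1, which carries no nitro, gives 20000 nM in this assay. The expected step is a 2.0-fold higher number from compound 2 to compound 4 (0.30 log units; within the scatter). Compound 4 is estimated at 8000 nM, between 2000 nM and 40000 nM.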

Compound 4, minimum cytotoxic concentration: 20000 nM
Beside the measured number, compound 4's estimate is 2.5-fold (0.40 log units) below it; the range from low to high includes it.
By their numbers in this assay, from the lowest: compound 2; then compounds 1 and 4 (each within the scatter of the next). At a limit, above all of these: compound 3.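

Methyl in place of nitro on the aromatic carbon gives a 5.0-fold higher number from compound 2 to compound 4 (0.70 log units; beyond the scatter) in this assay and is the only change shown here in a single place. It shows that the group at this position can alter how much compound the cells tolerate. Nothing measured here explains this step.

As far as these compounds go, it remains open whether the step follows from losing nitro or from gaining methyl. An amine, a chlorine or a plain hydrogen at the same place would help separate the two.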